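Sulfonyl group change from compound 2 to compound 4

The source may report more compounds than this note shows. Statements on the series, on what has been measured and on what is new or still open speak of the compounds shown alone.

In a functional assay on DU-145 cells (Homo sapiens) for inhibition, read by trypan blue exclusion, with a stated time of 72 h (on this read-out higher numbers stand for weaker inhibition and lower numbers for stronger inhibition), compound 2 (`Cn1c(=O)c(S(=O)(=O)c2ccc(C(=O)O)cc2)cc2cnc(Nc3ccc4[nH]ccc4c3)nc21`) gives 10000 nM as its value. Compound 1 (`COC(=O)Cn1c(=O)c(S(=O)(=O)c2ccc(F)cc2F)cc2cnc(Nc3ccc4[nH]ccc4c3)nc21`) gives 10000 nM and is level with it within the scatter, so the two share the highest number of the three. Compound 3 (`Cn1c(=O)c(S(=O)(=O)c2ccc(F)cc2F)cc2cnc(Nc3cccc4[nH]ccc34)nc21`) gives 750 nM and lies lower than compound 2, beyond the scatter.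

Compound 4 (`Cn1c(=O)c(S(=O)(=O)Cc2ccc(F)cc2)cc2cnc(Nc3ccc4[nH]ccc4c3)nc21`) carries 4-fluorobenzyl in place of 4-carboxyphenyl on a sulfonyl sulfur of compound 2 (4-fluorobenzyl in place of 4-carboxyphenyl on a sulfonyl sulfur).

Within the data shown here, no measured pair differs in one place only, so this assay offers no direct guide to this change. The expectation rests on the three values alone. Compound 2 (10000 nM) sits at the top of the range and compound 3 (750 nM) shows that lower numbers occur, so a downward step beyond the scatter is expected, though with wide uncertainty. The estimated change is a 6.7-fold lower number from compound 2 to compound 4 (0.82 log units; beyond the scatter) in this series.

For compound 4 the estimated value is 1500 nM, with an expected range from 250 nM to 10000 nM in this read-out.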

Compound 4, half-maximal inhibitory concentration: 30000 nM
Estimate against measurement, compound 4: 20-fold (1.30 log units) below, and the stated range ends below it.
By their numbers in this assay, from the lowest: compound 3; then compounds 1 and 2 (each within the scatter of the next); then compound 4.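

In this assay, the sulfonyl sulfur now has its first direct comparison: 4-fluorobenzyl in place of 4-carboxyphenyl gives a 3.0-fold higher number from compound 2 to compound 4 (0.48 log units; beyond the scatter). The value of compound 2, 10000 nM, is therefore not the upper end of what this read-out can show for the series, and this position can still move the number upward from there. The change replaces the whole group, so this single step does not separate the loss of the carboxy substituent from the gain of the fluoro substituent or the benzyl linkage.

Still open, going by these compounds, is how an unsubstituted phenyl, an unsubstituted benzyl or an aminophenyl on the sulfonyl sulfur would read, which would help to pull those parts apart. Nothing among the data given explains the rise in the number.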